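The source may hold more compounds than are shown below. What is called first, only, known or untested is meant among the compounds shown, and "the series" means these compounds.

Measured so far in a functional assay on the whole organism (stomach) with Rattus norvegicus as the target; on this read-out higher numbers stand for an effect only at larger amounts of compound and lower numbers for an effect already at smaller amounts:
Compound 1, `CCC/N=C(/NC#N)NCCCCn1nc(-c2ccccc2)ccc1=O`, gives a limit of the assay, > 100 mg/kg.
Compound 2, `N#CNC(=N)NCCCCn1nc(-c2ccccc2)ccc1=O`, gives 77.2 mg/kg.
Compound 3, `CC/N=C(/NC#N)NCCCn1nc(-c2ccccc2)ccc1=O`, gives 78.3 mg/kg.

Of the two numbers available, compound 3 stands highest, yet the nearest number lies within the scatter: a 1.0-fold higher number from compound 2 to compound 3 (0.01 log units; within the scatter). The value of compound 1 is a limit only (the limit of > 100 mg/kg in this assay, at which 1 of the 3 values shown sits), and the step of an at least 1.2-fold lower number from compound 1 to compound 2 (0.11 log units; that floor lies within the scatter) reaches no further than that floor.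

Compound 4, `CC/N=C(\S)NCCCCn1nc(-c2ccccc2)ccc1=O`, differs from compound 3 in one place: a group of 7 heavy atoms (4 carbon, 2 nitrogen, 1 sulfur; no ring) in place of a group of 8 heavy atoms (4 carbon, 4 nitrogen; no ring), on a saturated chain carbon, three bonds along the chain from an aromatic nitrogen. Neither measured step bears directly on this change. The step from compound 1 to compound 2 alters the group on the amine nitrogen, and the step from compound 2 to compound 3 alters the chain between the aromatic nitrogen and the rest, while both keep the group that compound 4 exchanges. Going by the values given here, with only two numbers, both close together and one value a limit, the expectation for compound 4 in this assay is a step of a 1.1-fold lower number from compound 3 to compound 4 (0.05 log units; within the scatter), not beyond the scatter. Compound 4 is therefore expected to give 70 mg/kg, with a range from 30 mg/kg to 160 mg/kg.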

Compound 4, dose for half-maximal effect: 37.2 mg/kg
The estimate for compound 4 lay 1.9-fold (0.27 log units) above the measured number, within the range that was stated.
By their numbers in this assay, from the lowest: compound 4; then compounds 2 and 3 (each within the scatter of the next). At a limit, above all of these: compound 1.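

In this assay, the exchange on the saturated chain carbon gives the first step beyond the scatter among these compounds: a 2.1-fold lower number from compound 3 to compound 4 (0.32 log units; beyond the scatter). The sulfur-bearing group entering on an amine nitrogen gives a step of the same size, a 2.1-fold lower number from compound 2 to compound 4 (0.32 log units; beyond the scatter), so compound 4 separates from both compounds 2 and 3, whose own numbers lie within the scatter of each other. Against compound 1 the step is only a floor, an at least 2.6-fold lower number from compound 1 to compound 4 (0.42 log units; beyond the scatter), and the value of compound 1 is a limit: the limit of > 100 mg/kg in this assay, at which 1 of the 4 values shown sits.

As far as these compounds go, whether the sulfur itself carries this step stays open, as would be tested by a urea with a carbonyl in its place. Also open, from the compounds shown here alone, is how a longer carbon chain on that nitrogen would read in this assay.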